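Tetrazole for carboxylic acid on a weak inhibitor scaffold

A few compounds are considered here, and "the series" means these few. Any claim that something is new, unique, unknown or untested is made for them only; others in the source may bear on it.

The series shares a benzyl-pyrrolidine amide core. Compound 1 `O=C(NO)c1ccc(COc2ccc(CNC(=O)[C@@H]3CCC(=O)N3Cc3ccccc3)cc2)cc1` gives 700 nM in an assay on HEK293 cells for inhibition of Ataxin-2 (Mus musculus), read by fluorescence and Amplex Red (a lower number here means a stronger inhibitor, a higher number a weaker inhibitor), and compound 3 `O=C(O)c1ccc(COc2ccc(CNC(=O)[C@@H]3CCCN3Cc3ccc(F)cc3)cc2)cc1` gives 800 nM. Compound 2 `O=C(O)c1ccc(COc2ccc(CNC(=O)[C@@H]3CCCN3Cc3ccccc3)cc2)cc1` reaches only the limit > 5000 nM, a limit of the assay rather than a number, as noted in the limit of > 5000 nM in this assay, at which 1 of the 3 values shown sits. Compound 4 `O=C(NCc1ccc(OCc2ccc(-c3nn[nH]n3)cc2)cc1)[C@@H]1CCCN1Cc1ccccc1` differs from compound 2 by 2H-tetrazol-5-yl in place of carboxy on an aromatic carbon. Within the data shown here, the only measured single change, an at least 6.2-fold lower number from compound 2 to compound 3 (0.79 log units; beyond the scatter), touches a different part of the molecule and so bears on compound 4 only in showing that small changes can lift this scaffold out of the limit. Compound 4 is therefore expected to remain weak, with an estimated a number no higher from compound 2 to compound 4 (the limit leaves the size open) and an expected value of 5000 nM between 1500 nM and 20000 nM.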

Compound 4, half-maximal inhibitory concentration: > 5000 nM
Compound 4 ended at the assay's limit (the forecaster's own chance of this, stated with the estimate: 50%); the middle value lies on the limit itself.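

Compound 2 and compound 4 both stand at a limit rather than at a number, so the step between them cannot be read: the limit of > 5000 nM in this assay, at which 2 of the 4 values shown sit.

The compounds shown leave open how 2H-tetrazol-5-yl and carboxy compare on this scaffold, and whether fluoro would lift compound 4 off the limit.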